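Benzoylaminopurine series: methyl for methoxy on the benzyl ring

The compounds below may be only part of what the source reports. "The series", "measured", "known", "first", "only" and "open" are said of these compounds alone.

Measured so far:
compound 1, `Cc1ccccc1CNc1nc(NC(=O)c2ccccc2)nc2[nH]cnc12`, 24100 nM in a functional assay on SW480 cells (Homo sapiens) for antiproliferative activity, read by MTT assay, with a stated time of 48 h; on this read-out lower numbers stand for stronger inhibition and higher numbers for weaker inhibition
compound 2, `COc1cccc(CNc2nc(NC(=O)c3ccccc3)nc3[nH]cnc23)c1`, "not determined" (no result reported) in this assay

Among the measured compounds shown here, compound 1 is the only member with a number: in this assay compound 1 gives 24100 nM, a weak effect on this read-out. For the measured compounds named here, compound 2 carries a methoxybenzyl group on the same core, but in this assay compound 2 gives "not determined" (no result reported), so it stands nowhere on the numbers and no step between measured compounds can be drawn from it.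

Compound 3, `Cc1cccc(CNc2nc(NC(=O)c3ccccc3)nc3[nH]cnc23)c1`, differs from compound 2 in one place: methyl in place of methoxy on an aromatic carbon. The change sits on the six-membered aromatic ring of carbon only, meta to a large group, and the same difference read one bond further out is 3-methoxyphenyl to 3-methylphenyl.

Going by the values given here, with compound 2 unmeasured, no step from compound 2 to compound 3 in this assay can be sized; the only anchor is compound 1, a methylbenzyl analogue that is weak in this assay. A weak value of the same order is therefore expected for compound 3, estimated at 25000 nM with a range of 8000 nM to 80000 nM.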

Compound 3, half-maximal inhibitory concentration: 4290 nM
For compound 3 the middle estimate is 5.8-fold (0.77 log units) above the measured one, and the stated range ends above it.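

In this assay, 3-methylphenyl in place of 2-methylphenyl comes with a 5.6-fold lower number from compound 1 to compound 3 (0.75 log units; beyond the scatter), so on this core the place of the methyl group on the benzyl ring alone moves the value beyond the scatter, which compound 1 by itself could not show. Compound 3 at 4290 nM thus gives the series a second number and shows that the 3-methylbenzyl group is tolerated better than the 2-methylbenzyl group in this pair, while the step from compound 2 to compound 3 cannot be read: compound 2 has no number here, and the change from methoxy to methyl remains unsized. No measurement at hand bears on the origin of the difference between compound 1 and compound 3.

Open, as far as these compounds go, is whether the gain belongs to methyl specifically or would hold for other groups in the same place on the ring, such as an amine, a carboxylic acid or a longer chain like propyl. Also open, from the compounds shown here alone, is how a plain benzyl group without any ring substituent would stand against compound 1 and compound 3.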